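A few compounds are considered here, and "the series" means these few. Any claim that something is new, unique, unknown or untested is made for them only; others in the source may bear on it.

Working notes on the series, read in a functional assay on NCI60 cells (Homo sapiens) for antiproliferative activity, read by sulforhodamine B assay, with a stated time of 48 h; on this read-out lower numbers stand for stronger inhibition of growth and higher numbers for weaker inhibition of growth. Compound 1 (`COc1cc(C2CC(=O)Nc3c(-c4ccccc4)nsc32)c(OC)c(O)c1O`) has no usable result, its entry reading "not determined" (no result reported). Compound 2 (`COc1ccc(-c2nsc3c2NC(=O)CC3c2cccc(OC)c2)cc1`) gives 1550 nM and compound 3 (`COc1ccc(-c2nsc3c2NC(=O)CC3c2ccc3c(c2)OCCO3)cc1`) gives 933 nM. Among the compounds with values here, these two values lie within the scatter of each other, so compound 2 stands level with the only other number available. Compound 4 (`COc1ccc(-c2nsc3c2NC(=O)CC3c2cccc(Cl)c2)cc1`) differs from compound 2 by chloro in place of methoxy on an aromatic carbon, meta to a large group: chloro in place of methoxy on an aromatic carbon. Within the data shown here, no measured pair shows this change, so no shift beyond the scatter is expected in this assay. The estimated step of a 1.3-fold lower number from compound 2 to compound 4 (0.11 log units; within the scatter) stays within the scatter. For compound 4 the estimated value is 1200 nM, with an expected range of 500 nM to 3000 nM.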

Compound 4, concentration for 50% growth inhibition: 1740 nM
Compound 4: middle estimate off by 1.5-fold (0.16 log units), on the low side; measured number inside the range.
By their numbers in this assay, from the lowest: compounds 3, 2 and 4 (each within the scatter of the next).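

In this assay, within the data shown here, the first measured change at this position, 3-methoxyphenyl to 3-chlorophenyl, gives a 1.1-fold higher number from compound 2 to compound 4 (0.05 log units; within the scatter) and so stays within the scatter. In this single pair, chloro in place of methoxy on an aromatic carbon, with one hydrogen-bond acceptor fewer, leaves the number level. No supporting data bear on this result.

From the compounds shown here alone, whether an amine, a carboxylic acid or a longer chain such as butoxy at this place would also keep the number level remains open. A single pair also leaves open whether the same change behaves alike on another member of the series.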